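The compounds below may be only part of what the source reports. "The series", "measured", "known", "first", "only" and "open" are said of these compounds alone.

Measured so far:
- compound 1, `CN1CCN(CC(=O)N2CCC3(N(C)C)CC(c4ccccc4)C2C(c2ccccc2)C3)CC1` — 195000 nM
- compound 2, `CN1CCN(CC(=O)N2CCC3(N4CCCCC4)CC(c4ccccc4)C2C(c2ccccc2)C3)CC1` — 177000 nM
- compound 3, `NC1CC2(N3CCCCC3)CC(c3ccccc3)C1C(c1ccccc1)C2` — 35000 nM

These three compounds were tested in an ADME assay on L6 cells (Rattus norvegicus) for cytotoxicity, read by resazurin assay, with a stated time of 72 h (a higher number here means a weaker inhibitor, a lower number a stronger inhibitor), which reports how strongly each one harms the cells. Compound 1 gives 195000 nM and compound 2 gives 177000 nM; the two differ by one change, (dimethylamino in place of piperidin-1-yl on a saturated ring carbon), and the step is a 1.1-fold higher number from compound 2 to compound 1 (0.04 log units; within the scatter). Compound 3 gives 35000 nM, the lowest of the three numbers, and its gap to compound 2 lies beyond the scatter. How the core of compound 3 differs from the core of compound 2 is not broken down here.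

The unmeasured compound 4, `CN(C)C12CC(N)C(C(c3ccccc3)C1)C(c1ccccc1)C2`, is made from compound 3 by dimethylamino in place of piperidin-1-yl on a saturated ring carbon. Going by the values given here, this is the same kind of change as the one from compound 2 to compound 1, but not the same: in compound 1 the altered carbon has two ring bonds from two ring atoms that each bear a phenyl group, while in compound 4 it has two ring bonds from the ring atom that bears a phenyl group and two ring bonds from the ring atom that bears an amino group. Because the earlier step of a 1.1-fold higher number from compound 2 to compound 1 (0.04 log units; within the scatter) stayed within the scatter, the step from compound 3 to compound 4 is expected to be small as well, about a 1.1-fold higher number from compound 3 to compound 4 (0.04 log units; within the scatter). Compound 4 is therefore estimated at 38000 nM in this assay, with a likely range from 18000 nM to 80000 nM.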

Compound 4, half-maximal inhibitory concentration: 40900 nM
Compound 4: the middle estimate sits 1.1-fold (0.03 log units) below what was measured; measured number inside the range.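

In this assay, putting dimethylamino in place of piperidin-1-yl on a saturated ring carbon gives a 1.2-fold higher number from compound 3 to compound 4 (0.07 log units; within the scatter), so the numbers for these two compounds cannot be told apart. Set beside the same swap on the other core, the result agrees, and the step carries over between these two cores with no detectable difference: the same change on two cores in this assay, a 1.1-fold higher number (0.04 log units; within the scatter) from compound 2 to compound 1 and a 1.2-fold higher number (0.07 log units; within the scatter) from compound 3 to compound 4, 1.1-fold (0.03 log units) apart, within the scatter of two such steps. Going by these compounds alone, this shows only that the swap had no measurable effect in this one cell test on these two cores; it does not show that the same would hold on a third core, and, with both steps within the scatter, it gives no reason to rank piperidin-1-yl against dimethylamino or to say why the two behave alike.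

The compounds shown leave open whether other amines on that saturated ring carbon, such as morpholin-4-yl, which carries an oxygen in its ring, or dibutylamino, with its longer chains, would also match piperidin-1-yl and dimethylamino. They also leave open whether the swap would stay this quiet on a core carrying a carboxylic acid where compound 3 and compound 4 carry their amino group.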